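Compound 4: a swapped phenyl group awaiting its number

The compounds below may be only part of what the source reports. "The series", "measured", "known", "first", "only" and "open" are said of these compounds alone.

In an ADME assay (liver) for metabolic stability, with Liver microsome (Rattus norvegicus) as the target, read by LC-MS, using microsomes and NADPH, with stated times of 5 min and 60 min, tested at 4 uM (a higher number here means that more of the compound is left, a lower number that less of the compound is left), compound 1 (`Cc1c(OCCCCOc2ccc(C(=O)O)cc2F)ccc(C(=O)CC2CCCC2)c1O`) gives 66%. Compound 2 (`Cc1c(OCCCCOc2ccc(C(=O)O)cc2F)ccc(C(=O)CC(C)C)c1O`) gives 57%, and compound 3 (`Cc1c(OCCCCOc2ccc(F)c(C(=O)O)c2)ccc(C(=O)CC(C)(C)C)c1O`) gives 58%. These three values lie within the usual scatter of one another, so compound 1 cannot be set apart from the other two. Compound 4 (`Cc1ccc(C(=O)O)cc1OCCCCOc1ccc(C(=O)CC2CCCC2)c(O)c1C`) differs from compound 1 in one place: 5-carboxy-2-methylphenyl in place of 4-carboxy-2-fluorophenyl on an oxygen on a saturated carbon. In words, 5-carboxy-2-methylphenyl stands in place of 4-carboxy-2-fluorophenyl on an oxygen on a saturated carbon. Among the measured compounds shown here, the only measured step that changes a single place is a number 9 percentage points lower from compound 1 to compound 2 (within the scatter), and that change lies elsewhere, on a saturated chain carbon bound to a carbonyl carbon. Compound 3 differs from compound 1 in more than one place, so it offers no clean comparison. No measurement tests the new group directly, so the range must stay wide. No shift beyond the scatter is expected, and the estimated step is a number 4 percentage points lower from compound 1 to compound 4 (within the scatter). For compound 4, the expected value is 62%, with an estimated range of 45% to 78%.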

Compound 4, percent of the compound remaining: 9%
Estimate against measurement, compound 4: 53 percentage points above; measured number below the stated range.
By their numbers in this assay, from the lowest: compound 4; then compounds 2, 3 and 1 (each within the scatter of the next).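

In this assay, among the compounds shown here, the group on an oxygen on a saturated carbon proves far more decisive than the earlier compounds could reveal: 5-carboxy-2-methylphenyl in place of 4-carboxy-2-fluorophenyl gives a number 57 percentage points lower from compound 1 to compound 4 (beyond the scatter). For the compounds shown here, the only earlier single-place step, a number 9 percentage points lower from compound 1 to compound 2 (within the scatter), lay elsewhere, and this new step shows that a large change can come from a swap between two groups with the same count of heavy atoms. Nothing available explains the size of this step.

The swap makes two changes at once: a methyl replaces the fluorine, and the carboxy group goes from the 4 to the 5 in the name, so the compounds shown do not separate their contributions. A 4-carboxy-2-methylphenyl group on the core of compound 1 would test the methyl alone.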